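The source may hold more compounds than are shown below. What is called first, only, known or untested is meant among the compounds shown, and "the series" means these compounds.

Measured compounds:
compound 1, `COc1ccc(S(=O)(=O)Nc2ccc(C)cc2Br)cc1N1CCNCC1`, 7.94 nM
compound 2, `COc1ccc(S(=O)(=O)Nc2ccc(Cl)c(Cl)c2)cc1N1CCNCC1`, 2.51 nM
compound 3, `COc1ccc(S(=O)(=O)Nc2cc(Br)cc(Br)c2Cl)cc1N1CCNCC1`, 2.51 nM

In an assay on isolated protein for binding affinity to 5-hydroxytryptamine receptor 6 (Homo sapiens) (a lower number here means a stronger inhibitor, a higher number a weaker inhibitor), compound 3 stands level with compound 2, the two sharing the lowest of the three numbers, while compound 1 sits furthest away: a 3.2-fold lower number from compound 1 to compound 3 (0.50 log units; beyond the scatter). Compound 4 `COc1ccc(S(=O)(=O)Nc2cc(F)cc(F)c2Cl)cc1N1CCNCC1` differs from compound 3 in one place: 2-chloro-3,5-difluorophenyl in place of 3,5-dibromo-2-chlorophenyl on a sulfonamide nitrogen. Going by the values given here, the steps that bear on this are the ones that alter the halogen pattern on the ring attached to the sulfonamide nitrogen: a 3.2-fold lower number from compound 1 to compound 2 (0.50 log units; beyond the scatter) and, between the two halogen-rich rings, no change at the digits printed from compound 2 to compound 3 (within the scatter). Exchanging bromine for fluorine at the same positions is therefore expected to move this assay little, with no clear direction. Compound 4 is expected to give 3.5 nM, within 1.5 nM to 9 nM, an expected step of a 1.4-fold higher number from compound 3 to compound 4 (0.14 log units; within the scatter).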

Compound 4, inhibition constant: 31.6 nM
Estimate against measurement, compound 4: 9.0-fold (0.96 log units) below, and the stated range ends below it.
By their numbers in this assay, from the lowest: compounds 2 and 3 (each within the scatter of the next); then compound 1; then compound 4.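

In this assay, the halogens on the ring on the sulfonamide nitrogen proved not to be interchangeable: fluorine in place of bromine gave a 13-fold higher number from compound 3 to compound 4 (1.10 log units; beyond the scatter), although the earlier change between halogen-rich rings had shown no shift. The 2-chloro-3,5-difluorophenyl ring also fell behind the other two rings, with a 13-fold higher number from compound 2 to compound 4 (1.10 log units; beyond the scatter) and a 4.0-fold higher number from compound 1 to compound 4 (0.60 log units; beyond the scatter), so it ranks below even 2-bromo-4-methylphenyl. On these data alone, how a ring carrying trifluoromethyl or nitrile groups in place of the fluorines would read remains open. Nothing available explains the loss.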